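The compounds below may be only part of what the source reports. "The series", "measured", "known", "first", "only" and "open" are said of these compounds alone.

Measured so far:
Compound 1, `COc1cc2c(Sc3ccc(NC(=O)NN4C(=O)CSC4c4c(F)cccc4F)cc3)ccnc2cc1OC1CCN(C(=O)NC(C)C)CC1`: 420 nM
Compound 2, `COc1cc2c(Sc3ccc(NC(=O)NN4C(=O)CSC4c4c(F)cccc4F)cc3)ccnc2cc1OC1CCCN(C(=O)NC(C)C)C1`: > 10000 nM, which is a limit of the assay rather than a number

For the measured compounds named here, in a functional assay on HT-29 cells (Homo sapiens) for inhibition, read by MTT assay (on this read-out lower numbers stand for stronger inhibition and higher numbers for weaker inhibition), compound 1 is the only compound with a measured number; the other value shown is a limit. Compound 2 gives only a limit in this assay. Going by the values given here, the single measured step, an at least 23-fold higher number from compound 1 to compound 2 (1.37 log units; beyond the scatter), runs into (the limit of > 10000 nM in this assay, at which 1 of the 2 values shown sits), so its true size is not known beyond being large. Compound 3, `COc1cc2c(Sc3ccc(NC(=O)NN4C(=O)CSC4c4c(F)cccc4F)cc3)cc(N)nc2cc1OC1CCN(C(=O)NC(C)C)CC1`, is derived from compound 1 by a different kind of change: amino in place of hydrogen on an aromatic carbon. Among the compounds with values here, the step from compound 1 to compound 2 altered the attachment of the piperidine ring on the oxygen, a different part of the molecule, and so offers no direct guide to the effect of an amino group; no measured step touches this aromatic carbon. With nothing pointing in either direction, the expectation is a step within the scatter of this assay, a 1.2-fold higher number from compound 1 to compound 3 (0.08 log units; within the scatter). Compound 3 is therefore estimated at 500 nM in this assay, with a range from 150 nM to 2500 nM.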

Compound 3, half-maximal inhibitory concentration: 5600 nM
Estimate against measurement, compound 3: 11-fold (1.05 log units) below; the measured number lies above the stated range.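

In this assay, the aromatic carbon next to the ring nitrogen proves sensitive to change: amino in place of hydrogen there gives a 13-fold higher number from compound 1 to compound 3 (1.12 log units; beyond the scatter). For the compounds shown here, a change of one heavy atom on the shared core is thus enough to weaken inhibition clearly, which the earlier compounds could not show, as they differ only in how the piperidine ring is attached on the oxygen. Compound 2 remains a limit and not a number, whereas compound 3 has a measured value, so this new step can be read at its full size, still short of the ceiling of the read-out: the limit of > 10000 nM in this assay, at which 1 of the 3 values shown sits.

Going by these compounds, whether a methyl group or a chlorine atom on this carbon would bring a step of like size, or whether the effect belongs to the amino group alone, remains open. On these data alone, the reason for the step also remains open, as does how amino on this carbon would read alongside the 1-(isopropylcarbamoyl)piperidin-3-yl group of compound 2.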